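The source may report more compounds than this note shows. Statements on the series, on what has been measured and on what is new or still open speak of the compounds shown alone.

In a functional assay on MCF7 cells (Homo sapiens) for cytotoxicity, read by MTT assay, with a stated time of 72 h (on this read-out lower numbers stand for stronger inhibition and higher numbers for weaker inhibition), compound 1 `Cc1cc(=O)n(-c2cccc(F)c2)nc1C(=O)Nc1ccc(Oc2ncnc3c2ccn3C)cc1` gives 30800 nM. Compound 2 `Cc1cc(=O)n(-c2ccc(Br)cc2F)nc1C(=O)Nc1ccc(Oc2ncnc3c2ccn3C)c(F)c1` reaches only the limit of this assay, > 60000 nM, which is a boundary of the measurement rather than a number. Among the values shown, compound 2 stands at the limit of > 60000 nM in this assay, at which 1 of the 2 values shown sits. Compound 3 `Cc1cc(=O)n(-c2cccc(F)c2)nc1C(=O)Nc1ccc(Oc2ncnc3c2ccn3C)c(F)c1` has not yet been measured. It differs from compound 2 by 3-fluorophenyl in place of 4-bromo-2-fluorophenyl on an aromatic nitrogen. Going by the values given here, no step between two measured compounds covers this exchange, so the data give no size for it; compound 1, which carries the same 3-fluorophenyl, gives 30800 nM. Starting from a limit, the step expected is an at least 1.3-fold lower number from compound 2 to compound 3 (0.12 log units; that floor lies within the scatter), a move that may well stay within the ordinary scatter. Compound 3 is therefore estimated at 45000 nM, with a likely range from 15000 nM to 120000 nM, and a fair chance that this assay again reports only a limit.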

Compound 3, half-maximal inhibitory concentration: > 60000 nM
Compound 3: no number, only a limit; the forecaster's own chance of this, stated with the estimate: 40%; middle value at least 1.3-fold (0.12 log units) away from the limit.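

Compound 2 and compound 3 both end at a limit rather than a number in this assay, so the exchange of 4-bromo-2-fluorophenyl for 3-fluorophenyl on the aromatic nitrogen cannot be read, and losing the bromine does not bring a number back: the limit of > 60000 nM in this assay, at which 2 of the 3 values shown sit.

The new information comes from the other comparison, fluoro in place of hydrogen on an aromatic carbon of the shared core, which gives an at least 1.9-fold higher number from compound 1 to compound 3 (0.28 log units; that floor lies within the scatter). That floor stays within the scatter, so the data do not establish that this single fluoro weakens the compound.

Going by these compounds, whether a plain phenyl or a pyridyl on the aromatic nitrogen, or a chloro or methoxy in place of that fluoro, would give a number clear of the limit stays open. Only compounds with readable numbers on both sides of a step could size either change.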